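Swapping the Side Chain of Compound 3

The source may report more compounds than this note shows. Statements on the series, on what has been measured and on what is new or still open speak of the compounds shown alone.

In a functional assay (trachea) with Cavia porcellus as the target (a higher number here means a weaker inhibitor, a lower number a stronger inhibitor), compound 1 (`CCn1nc(-c2cccnc2)c2ccccc2c1=O`) gives 1320 nM, compound 2 (`CCCn1nc(-c2cccnc2)c2ccccc2c1=O`) gives 3160 nM and compound 3 (`O=c1c2ccccc2c(-c2cccnc2)nn1Cc1cccc(Cl)c1`) gives 4170 nM. Compound 3 therefore stands level with compound 2 at the upper end of these numbers, and compound 1 is the strongest inhibitor of the three.

Compound 4 (`O=c1c2ccccc2c(-c2cccnc2)nn1CCSc1ccccc1`) keeps the shared core and carries (phenylsulfanyl)methyl in place of 3-chlorophenyl on a saturated chain carbon bound to an aromatic nitrogen.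

For the measured compounds named here, three measured steps concern this same part of the molecule. Two start from compound 1 and are modest and upward: a 2.4-fold higher number from compound 1 to compound 2 (0.38 log units; beyond the scatter), and a 3.2-fold higher number from compound 1 to compound 3 (0.50 log units; beyond the scatter). The third replaces ethyl with 3-chlorophenyl and shows a 1.3-fold higher number from compound 2 to compound 3 (0.12 log units; within the scatter), which stays within the scatter. Going by the values given here, that last step is the closest guide, although no measured step exchanges one ring-bearing group for another. With so little evidence, no shift beyond the scatter is expected in this assay, in either direction.

The expected change is a 1.0-fold lower number from compound 3 to compound 4 (0.02 log units; within the scatter). For compound 4 the estimated value is 4000 nM, with an expected range from 1500 nM to 11000 nM.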

Compound 4, half-maximal inhibitory concentration: 9120 nM
The estimate for compound 4 lay 2.3-fold (0.36 log units) below the measured number; the measured number falls inside the stated range.
By their numbers in this assay, from the lowest: compound 1; then compounds 2 and 3 (each within the scatter of the next); then compound 4.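

The exchange of one ring-bearing group for another at this position, a saturated chain carbon bound to an aromatic nitrogen, moves the number beyond the scatter in this assay, with a 2.2-fold higher number from compound 3 to compound 4 (0.34 log units; beyond the scatter), whereas the earlier change from ethyl to 3-chlorophenyl did not. Compound 4 is thus the weakest inhibitor of the four, with a 2.9-fold higher number from compound 2 to compound 4 (0.46 log units; beyond the scatter) and a 6.9-fold higher number from compound 1 to compound 4 (0.84 log units; beyond the scatter), so the (phenylsulfanyl)methyl group takes the series further from compound 1 than either compound 2 or compound 3 did, although this step remains modest. The data offer no explanation for this rise.

The step from compound 3 to compound 4 removes the chlorine and brings in both the sulfur and an extra chain carbon, so the compounds shown cannot assign the rise to any one of these changes. From the compounds shown here alone, it remains open how a side chain with an oxygen ether in place of the sulfur, an unsubstituted benzyl group, or a terminal amine or carboxylic acid would behave here, and whether any group at this position can give a lower number than compound 1.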